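A few compounds are considered here, and "the series" means these few. Any claim that something is new, unique, unknown or untested is made for them only; others in the source may bear on it.

Of the compounds shown here, three built on one shared core have been tested in a functional assay on SW480 cells (Homo sapiens) for cytotoxicity, read by MTT assay, with a stated time of 48 h; on this read-out lower numbers stand for stronger inhibition and higher numbers for weaker inhibition. Compound 1 `O=c1ccoc2cc(OCc3cn(Cc4cccc(F)c4)nn3)ccc12` gives > 100000 nM in this assay, and that figure is a limit of the assay rather than a number (the limit of > 100000 nM in this assay, at which 1 of the 3 values shown sits). Compound 2 `O=c1ccoc2cc(OCc3cn(Cc4cccc(Cl)c4)nn3)ccc12` gives 12900 nM in this assay, while compound 3 `O=c1ccoc2cc(OCc3cn(Cc4ccccc4Cl)nn3)ccc12` gives 23500 nM. Compound 3 differs from compound 2 by 2-chlorophenyl in place of 3-chlorophenyl on a saturated chain carbon bound to an aromatic nitrogen, and that step came out as a 1.8-fold higher number from compound 2 to compound 3 (0.26 log units; within the scatter). Compound 1 differs from compound 2 by fluoro in place of chloro on an aromatic carbon, a swap sitting meta to a large group, and that step came out as an at least 7.7-fold higher number from compound 2 to compound 1 (0.88 log units; beyond the scatter).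

Compound 4 `O=c1ccoc2cc(OCc3cn(Cc4ccccc4F)nn3)ccc12` has not yet been measured. It differs from compound 3 by fluoro in place of chloro on an aromatic carbon, the same kind of change as before, though here the place is ortho to a large group rather than meta. Compound 4 is expected to show a step of a 4.3-fold higher number from compound 3 to compound 4 (0.63 log units; beyond the scatter), an expectation resting on the earlier step of an at least 7.7-fold higher number from compound 2 to compound 1 (0.88 log units; beyond the scatter). Compound 4 is therefore estimated at 100000 nM, with a range from 30000 nM to 400000 nM, and a limit rather than a number would not be surprising.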

Compound 4, half-maximal inhibitory concentration: 11400 nM
Compound 4: middle estimate off by 8.8-fold (0.94 log units), on the high side; measured number below the stated range.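

In this assay, fluoro in place of chloro does not carry a fixed effect from one core to another in this series, and the two steps even point opposite ways: the same change on two cores in this assay, an at least 7.7-fold higher number (0.88 log units; beyond the scatter) from compound 2 to compound 1 and a 2.1-fold lower number (0.31 log units; beyond the scatter) from compound 3 to compound 4, at least 15-fold (1.20 log units) apart, beyond the scatter of two such steps

Compound 1 gives > 100000 nM in this assay, which is a limit of the assay and not a number.

The new step, a 2.1-fold lower number from compound 3 to compound 4 (0.31 log units; beyond the scatter), stands with a 1.1-fold lower number from compound 2 to compound 4 (0.05 log units; within the scatter) and an at least 8.7-fold lower number from compound 1 to compound 4 (0.94 log units; beyond the scatter), but these compounds show neither why the swap behaves differently in compound 4, where the place is ortho to a large group, nor how it would behave at any other place on the ring.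

From the compounds shown here alone, only two halogens on the phenyl ring appear here, so it remains open how a bromo, a methoxy or a nitrile would behave in the same place, and what the plain unsubstituted phenyl ring would give. Going by these compounds, it is also open whether a longer chain to that ring would change how much the choice of halogen matters.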